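Chloro in place of nitro on a shared core

The compounds below may be only part of what the source reports. "The series", "measured", "known", "first", "only" and "open" are said of these compounds alone.

Compound 1 `Cc1cccc(-c2nccc3nc(N)nn23)c1`: 5500 nM
Compound 2 `Nc1nc2ccnc(-c3cccc([N+](=O)[O-])c3)n2n1`: 3800 nM

Going by the values given here, in a functional assay (Homo sapiens) (a higher number here means a weaker inhibitor, a lower number a stronger inhibitor), compound 2 stands level with compound 1, the only other compound measured so far, as the two values lie within the scatter of each other. Compound 3 `Nc1nc2ccnc(-c3cccc(Cl)c3)n2n1` keeps the shared core of compound 2 but carries chloro in place of nitro on an aromatic carbon, meta to a large group: chloro in place of nitro on an aromatic carbon. Chloro itself has not yet been measured on this core. Among the compounds with values here, the only measured step that bears on the change is a 1.4-fold lower number from compound 1 to compound 2 (0.16 log units; within the scatter), with nitro in place of methyl on an aromatic carbon. On that evidence, no step beyond the scatter is expected in either direction. The expected step is a 1.1-fold higher number from compound 2 to compound 3 (0.02 log units; within the scatter). For compound 3 the estimated value is 4000 nM, within an expected range of 1500 nM to 11000 nM.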

Compound 3, half-maximal inhibitory concentration: 4300 nM
Beside the measured number, compound 3's estimate is 1.1-fold (0.03 log units) below it; measured number inside the range.
By their numbers in this assay, from the lowest: compounds 2, 3 and 1 (each within the scatter of the next).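

In this assay the aromatic carbon meta to a large group has now carried methyl, nitro and chloro, and all three values lie within the scatter of one another. Chloro in place of nitro gives a 1.1-fold higher number from compound 2 to compound 3 (0.05 log units; within the scatter) and chloro in place of methyl gives a 1.3-fold lower number from compound 1 to compound 3 (0.11 log units; within the scatter) on the same shared core. The exchange of nitro, with its 3 heavy atoms and 2 hydrogen-bond acceptors, for chloro, with 1 heavy atom and no hydrogen-bond acceptors, thus brings no step beyond the scatter at this position. As far as these compounds go, whether an amine or a carboxylic acid on this aromatic carbon would move the number beyond the scatter remains open. Nothing in the data shown offers an explanation for these values.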